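The compounds below may be only part of what the source reports. "The series", "measured", "known", "first", "only" and "open" are said of these compounds alone.

Of the compounds shown here, two sharing one core have been measured in a functional assay on CHO-K1 cells for antagonist activity at melanin-concentrating hormone receptor 1 (Homo sapiens), read by inositol phosphate accumulation, with stated times of 10 min and 45 min; on this read-out higher numbers stand for weaker inhibition and lower numbers for stronger inhibition. Compound 1, `C/C(=C\C(=O)Nc1ccc2nc(N3CCC(O)CC3)nc(C)c2c1)c1ccc(Cl)cc1`, gives 227 nM in this assay. Compound 2, `CCCC1(O)CCN(c2nc(C)c3cc(NC(=O)/C=C/c4ccc(Cl)cc4)ccc3n2)CC1`, gives 91 nM in this assay, the lowest of the two numbers; the nearest number is that of compound 1, which is higher by a margin beyond the usual scatter. Among the measured compounds shown here, no pair of measured compounds differs in only one place, so no single step can be read from the measured numbers.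

The unmeasured compound 3, `Cc1nc(N2CCC(O)CC2)nc2ccc(NC(=O)/C=C/c3ccc(Cl)cc3)cc12`, departs from compound 2 by one change: hydrogen in place of propyl on a saturated ring carbon. Compound 1 carries the same 4-hydroxypiperidin-1-yl group, and in this assay compound 1 gives 227 nM. For the measured compounds named here, that is the only guide available. On that basis a modest rise in the number is expected for the step of a 1.6-fold higher number from compound 2 to compound 3 (0.22 log units; within the scatter), one that may well remain within the scatter. Compound 3 is therefore estimated at 150 nM in this assay, with a range from 50 nM to 450 nM.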

Compound 3, half-maximal inhibitory concentration: 73 nM
The estimate for compound 3 lay 2.1-fold (0.31 log units) above the measured number; the range from low to high includes it.
By their numbers in this assay, from the lowest: compounds 3 and 2 (each within the scatter of the next); then compound 1.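

In this assay, the change from 4-hydroxy-4-propylpiperidin-1-yl to 4-hydroxypiperidin-1-yl gives a 1.2-fold lower number from compound 2 to compound 3 (0.10 log units; within the scatter) and so shows that, on this saturated ring carbon, propyl and hydrogen cannot be told apart on this read-out. Among the compounds shown here, with 4-hydroxypiperidin-1-yl held constant, 2-(4-chlorophenyl)ethenyl in place of 2-(4-chlorophenyl)prop-1-en-1-yl on a carbonyl carbon gives a 3.1-fold lower number from compound 1 to compound 3 (0.49 log units; beyond the scatter) and is the only single change here that reaches beyond the scatter, which makes the carbonyl substituent, rather than the ring carbon, the place where a difference can be read so far. No measured evidence bears on why either step has the size it has.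

On these data alone, whether a group of another kind on the same ring carbon, such as an amine, a carboxylic acid or a chain longer than propyl, would also stay within the scatter of hydrogen remains open. The compounds shown also leave open what the hydroxyl contributes, since all of them carry it and none has a methoxy group or a fluorine atom in its place.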